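This account rests on a few compounds, and the source may have more. Where it says the series, first, only, none or still open, it means among the compounds named here.

Of the compounds shown here, three share one core and have been measured in a functional assay on HT-29 cells (Homo sapiens) for antiproliferative activity, read by MTT assay, with a stated time of 72 h; a lower number here means a stronger inhibitor, a higher number a weaker inhibitor. Compound 1 `O=C(Nc1ccc(Oc2ccnc3[nH]ccc23)c(F)c1)c1cc2cccnc2n(-c2ccccc2)c1=O` gives 160 nM. Within the data shown here, compound 2 `COc1ccc(-n2c(=O)c(C(=O)Nc3ccc(Oc4ccnc5[nH]ccc45)c(F)c3)cc3cccnc32)cc1` gives 540 nM, and the single change, a 3.4-fold higher number from compound 1 to compound 2 (0.53 log units; beyond the scatter), is the only step here that clears the scatter. Compound 3 `O=C(Nc1ccc(Oc2ccnc3[nH]ccc23)c(F)c1)c1cc2cccnc2n(-c2ccc(F)c(Cl)c2)c1=O` gives 310 nM; its value lies within the scatter of both neighbours, as a 1.9-fold higher number from compound 1 to compound 3 (0.29 log units; within the scatter) and a 1.7-fold lower number from compound 2 to compound 3 (0.24 log units; within the scatter) show, so compound 3 cannot be ranked against compound 1 or compound 2 on these numbers.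

Compound 4 `O=C(Nc1ccc(Oc2ccnc3[nH]ccc23)c(F)c1)c1cc2cccnc2n(-c2ccc(Br)cc2F)c1=O` carries the change (4-bromo-2-fluorophenyl in place of 3-chloro-4-fluorophenyl on an aromatic nitrogen). The two steps that bear on it are those that vary the aryl group on the same aromatic nitrogen, from compound 1 to compound 3 and from compound 2 to compound 3, and both stayed within the scatter. No step beyond the scatter is therefore expected in this assay for compound 4. The estimate for compound 4 is 300 nM, with a range from 140 nM to 650 nM, which means an expected step of a 1.0-fold lower number from compound 3 to compound 4 (0.01 log units; within the scatter).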

Compound 4, half-maximal inhibitory concentration: 820 nM
Compound 4: middle estimate off by 2.7-fold (0.44 log units), on the low side; measured number above the stated range.
By their numbers in this assay, from the lowest: compounds 1, 3, 2 and 4 (each within the scatter of the next, the first and the last beyond it).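

Among these compounds, the aromatic nitrogen proved sensitive to more than the earlier compounds showed: in this assay, exchanging one halogenated aryl group for another gave a 2.6-fold higher number from compound 3 to compound 4 (0.42 log units; beyond the scatter), although 3-chloro-4-fluorophenyl and 4-bromo-2-fluorophenyl match in heavy-atom count, ring type and hydrogen-bond counts. Measured against the plain phenyl group, the change gave a 5.1-fold higher number from compound 1 to compound 4 (0.71 log units; beyond the scatter), the largest step in the set, whereas a 1.5-fold higher number from compound 2 to compound 4 (0.18 log units; within the scatter) leaves compound 4 and compound 2 unranked. Nothing available accounts for these differences.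

Because the bromine and the fluorine placement differ together, the compounds shown cannot separate their contributions. From the compounds shown here alone, whether an amine or a carboxylic acid on this aryl ring, or an alkyl chain in its place, would give a lower number than compound 1 remains open.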